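Replacing phenyl with 1,3-thiazol-2-yl on the sulfonamide nitrogen

The compounds below may be only part of what the source reports. "The series", "measured", "known", "first", "only" and "open" are said of these compounds alone.

In a functional assay on RAW264.7 cells (Mus musculus) for inhibition (on this read-out higher numbers stand for weaker inhibition and lower numbers for stronger inhibition), compound 1 (`CCOC(=O)C1=CCCCC1S(=O)(=O)Nc1ccccc1`) gives 260 nM as the highest number of the three measured compounds, which makes it the weakest inhibitor among them. Compound 2 (`CCOC(=O)C1=CCCCC1S(=O)(=O)Nc1cc(F)c(F)cc1F`) gives 30 nM and compound 3 (`CCOC(=O)C1=CCCCC1S(=O)(=O)Nc1ccc(C)cc1Cl`) gives 41 nM as two values within the scatter of each other, both lower than that of compound 1 by more than the scatter.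

Compound 4 (`CCOC(=O)C1=CCCCC1S(=O)(=O)Nc1nccs1`) has not yet been measured. Within the data shown here, it keeps the core of compound 1 and carries 1,3-thiazol-2-yl in place of phenyl on a sulfonamide nitrogen as its only change. Among the measured compounds shown here, no measured pair differs in one place only, and every measured compound has a six-membered aromatic ring of carbon only at that place, so the data offer no direct guide to this replacement. The low numbers of compound 2 at 30 nM and compound 3 at 41 nM both come with that ring and added groups, and compound 4 has neither. A moderate rise in the number is therefore expected, meaning weaker inhibition, and the expected size is a 1.7-fold higher number from compound 1 to compound 4 (0.24 log units; within the scatter) with wide uncertainty. Compound 4 is estimated at 450 nM with an expected range from 90 nM to 2500 nM as the working figure.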

Compound 4, half-maximal inhibitory concentration: > 10000 nM
Compound 4 ended at the assay's limit (the forecaster's own chance of this, stated with the estimate: 5%); middle value at least 22-fold (1.34 log units) away from the limit.
By their numbers in this assay, from the lowest: compounds 2 and 3 (each within the scatter of the next); then compound 1. At a limit, above all of these: compound 4.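

At the sulfonamide nitrogen, the exchange of phenyl for 1,3-thiazol-2-yl is far from neutral in this assay: this single change gives an at least 38-fold higher number from compound 1 to compound 4 (1.58 log units; beyond the scatter), so the shared core with the ethyl ester is not enough to keep inhibition at this read-out, and the group on that nitrogen can decide whether any number is obtained at all. Compound 4 stands at a limit of the assay, > 10000 nM, and this is a limit, not a number. The step therefore gives only a lower bound on the loss, and its true size cannot be read: the limit of > 10000 nM in this assay, at which 1 of the 4 values shown sits.

Among these compounds, the single pair leaves open whether the loss goes with the five-membered ring, with its ring nitrogen or with its ring sulfur, and a pyridyl or a thienyl group on the sulfonamide nitrogen would separate these readings. Also open, from the compounds shown here alone, is whether fluoro or methyl groups, as carried on the six-membered rings of compound 2 and compound 3, would restore inhibition when placed on the 1,3-thiazol-2-yl ring.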